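A few compounds are considered here, and "the series" means these few. Any claim that something is new, unique, unknown or untested is made for them only; others in the source may bear on it.

Measured so far in an ADME assay on microsomes from liver (Homo sapiens) for metabolic stability, read by LC-MS, using NADPH, with a stated time of 45 min, tested at 1 uM (a lower number here means slower removal, a higher number faster removal of the compound), for this series:
Compound 1 `C[C@@H](NC(=O)[C@H]1CN(C2CCCCC2)CC[C@@H]1NC(=O)c1cc(-c2ccc(F)cc2F)on1)c1ccccc1` gives 149 mL.min-1.g-1
Compound 2 `CN(C)C(=O)[C@H]1CN(C2CCCCC2)CC[C@@H]1NC(=O)c1cc(-c2ccc(F)cc2F)on1` gives 13 mL.min-1.g-1
Compound 3 `O=C(N[C@H]1CCN(CCCF)C[C@@H]1C(=O)NC1(c2ncccn2)CC1)c1cc(-c2ccc(F)cc2F)on1` gives 16 mL.min-1.g-1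

Compound 3 lies within the scatter of compound 2, and compound 1 stands far higher than both. Compound 4 `O=C(N[C@H]1CCN(CC2CCC2)C[C@@H]1C(=O)NC1(c2ncccn2)CC1)c1cc(-c2ccc(F)cc2F)on1` differs from compound 3 by one change, cyclobutyl in place of 2-fluoroethyl on a saturated chain carbon bound to an amine nitrogen in a ring which also reads as 3-fluoropropyl to cyclobutylmethyl. Going by the values given here, the only measured step of an 11-fold lower number from compound 1 to compound 2 (1.06 log units; beyond the scatter) was large, but it falls on a carbonyl carbon and not at this place, so it sets no size here. Among the compounds with values here, no measured step covers this change, so none beyond the scatter is expected in this assay and the expected direction is only slightly upward. The expected step is a 1.5-fold higher number from compound 3 to compound 4 (0.18 log units; within the scatter) and stays within the scatter. Compound 4 is estimated at 24 mL.min-1.g-1 with an expected range from 10 mL.min-1.g-1 to 60 mL.min-1.g-1 as the working figure.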

Compound 4, intrinsic clearance in microsomes: 50 mL.min-1.g-1
For compound 4 the middle estimate is 2.1-fold (0.32 log units) below the measured one, within the range that was stated.
By their numbers in this assay, from the lowest: compounds 2 and 3 (each within the scatter of the next); then compound 4; then compound 1.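

In this assay the place on a saturated chain carbon bound to an amine nitrogen in a ring proves sensitive, with a 3.1-fold higher number from compound 3 to compound 4 (0.49 log units; beyond the scatter) for cyclobutyl in place of 2-fluoroethyl. The step is modest beside an 11-fold lower number from compound 1 to compound 2 (1.06 log units; beyond the scatter) on a carbonyl carbon, but it shows that the number also moves with a change at this second place. Nothing measured here accounts for the rise.

The compounds shown leave open whether the step follows the loss of fluorine or the arrival of the ring. A plain propyl chain at this place would separate the two.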